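Taking the (dimethylamino)methyl group off compound 2

This account rests on a few compounds, and the source may have more. Where it says the series, first, only, none or still open, it means among the compounds named here.

Compound 1 `Cc1ncc(-c2cnc(NCc3c(F)ccc4c3CCO4)c3cn[nH]c(=O)c23)n1C`: 15000 nM
Compound 2 `Cc1nc(CN(C)C)ccc1-c1cnc(NCc2c(F)ccc3c2CCO3)c2cn[nH]c(=O)c12`: > 1000000 nM (a limit)

In a physicochemical assay for solubility, read by LC-MS, in phosphate buffer, with a stated time of 24 h, at pH 7.4 (on this read-out lower numbers stand for lower solubility and higher numbers for higher solubility), compound 2 stands at a limit of the assay and not at a number: > 1000000 nM. Compound 3 `Cc1ncccc1-c1cnc(NCc2c(F)ccc3c2CCO3)c2cn[nH]c(=O)c12` shares its core and changes in one place: hydrogen in place of (dimethylamino)methyl on an aromatic carbon. In words, hydrogen sits in place of (dimethylamino)methyl on an aromatic carbon, leaving 2-methylpyridin-3-yl. Among the compounds with values here, only one measured step bears on this change: an at least 66-fold higher number from compound 1 to compound 2 (1.82 log units; beyond the scatter). That step was large and beyond the scatter, and it brought in the (dimethylamino)methyl group along with a new ring group, so it does not isolate this group. On that basis, a large step to a lower number in this assay, meaning lower solubility, is expected. The expected change is an at least 83-fold lower number from compound 2 to compound 3 (1.92 log units; beyond the scatter). Compound 3 is estimated at 12000 nM, with an expected range from 2500 nM to 60000 nM.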

Compound 3, solubility: < 2000 nM
Compound 3 gave a limit, no number; the forecaster's own chance of this, stated with the estimate: 5%; middle value at least 6.0-fold (0.77 log units) away from the limit.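

With (dimethylamino)methyl replaced by hydrogen and 2-methylpyridin-3-yl left behind, this assay shows an at least 500-fold lower number from compound 2 to compound 3 (2.69 log units; beyond the scatter), so this single change, with the rest of the structure unchanged, is a large step. Putting 2-methylpyridin-3-yl in place of 1,2-dimethyl-1H-imidazol-5-yl without the (dimethylamino)methyl group gives an at least 7.5-fold lower number from compound 1 to compound 3 (0.87 log units; beyond the scatter), the opposite direction to the earlier rise, so the ring swap alone does not account for that rise. Compound 3 sits at a limit, so the true size of both steps remains unknown: the limit of < 2000 nM in this assay, at which 1 of the 3 values shown sits.

Going by these compounds, compound 2 also sits at a limit, so the full height of its number remains open: the limit of > 1000000 nM in this assay, at which 1 of the 3 values shown sits. Also open is where a primary amine, a morpholine or a carboxylic acid at this place would fall on this read-out, and whether (dimethylamino)methyl would give a similar step on another ring.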